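This account rests on a few compounds, and the source may have more. Where it says the series, first, only, none or still open, it means among the compounds named here.

Measured compounds in a functional assay on HepG2 cells (Homo sapiens) for antiproliferative activity, read by MTT assay, with a stated time of 48 h; a higher number here means a weaker inhibitor, a lower number a stronger inhibitor:
Compound 1 `Cc1ccccc1-n1nncc1CN1C(=O)C2(C(C#N)=C(N)Oc3c2c2nc4ccccc4nc2c2ccccc32)c2ccccc21` gives > 50000 nM, a limit of the assay.
Compound 2 `N#CC1=C(N)Oc2c(c3nc4ccccc4nc3c3ccccc23)C12C(=O)N(Cc1cnnn1-c1cccc(S(N)(=O)=O)c1)c1ccccc12` gives 21500 nM.
Compound 3 `N#CC1=C(N)Oc2c(N)cc3nc4ccccc4nc3c2C12C(=O)N(Cc1cnnn1-c1ccc(F)cc1)c1ccccc12` gives > 50000 nM, a limit of the assay.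

Compound 3 therefore has no measured number in this assay, only the limit > 50000 nM, and it shares that position with one other compound, as the limit of > 50000 nM in this assay, at which 2 of the 3 values shown sit, shows. Compound 4 `COc1ccccc1-n1nncc1CN1C(=O)C2(C(C#N)=C(N)Oc3c(N)cc4nc5ccccc5nc4c32)c2ccccc21` differs from compound 3 in a single place: 2-methoxyphenyl in place of 4-fluorophenyl on an aromatic nitrogen. For the measured compounds named here, only one measured step changes the group on this aromatic nitrogen, namely an at least 2.3-fold lower number from compound 1 to compound 2 (0.36 log units; beyond the scatter), and that step swaps different groups than the one at hand; it also starts from a limit, so its true size is not known. Compound 1, which carries 2-methylphenyl on the same nitrogen, sits at the limit, so an aryl group of this kind has not yet produced a measurable number in this series. Since compound 3 is also at the limit, the expected step of a number no higher from compound 3 to compound 4 (the limit leaves the size open) is none beyond the scatter, with the result most likely again a limit. The estimate for compound 4 in this assay is 50000 nM, expected between 20000 nM and 120000 nM.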

Compound 4, half-maximal inhibitory concentration: > 50000 nM
Compound 4 was reported as a limit; the forecaster's own chance of this, stated with the estimate: 70%; the middle value sits exactly at the limit.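

Compound 3 and compound 4 both sit at a limit in this assay, so the swap of 4-fluorophenyl for 2-methoxyphenyl gives no step that can be read, and this limit is a crowded position: the limit of > 50000 nM in this assay, at which 3 of the 4 values shown sit.

The compounds shown leave open how far each of the two lies past that limit, and whether the two groups differ at all.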